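A few compounds are considered here, and "the series" means these few. Any claim that something is new, unique, unknown or untested is made for them only; others in the source may bear on it.

Of the compounds shown here, three built on one shared core have been measured in a functional assay on CEM-DNR-bulk cells (Homo sapiens), read by MTT assay, with a stated time of 72 h; a higher number here means a weaker inhibitor, a lower number a stronger inhibitor. Compound 1 `COc1ncnc2c1c(-c1ccsc1)cn2[C@@H]1O[C@H](CO)[C@@H](O)[C@H]1O` gives 7640 nM. Compound 2 `C#Cc1cn([C@@H]2O[C@H](CO)[C@@H](O)[C@H]2O)c2ncnc(OC)c12` gives 3490 nM. Compound 3 `COc1ncnc2c1c(-c1cc3ccccc3o1)cn2[C@@H]1O[C@H](CO)[C@@H](O)[C@H]1O` gives 10800 nM, the highest of the three numbers; one measured step is a 1.4-fold higher number from compound 1 to compound 3 (0.15 log units; within the scatter), so those two cannot be told apart, while another is a 3.1-fold higher number from compound 2 to compound 3 (0.49 log units; beyond the scatter).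

Compound 4 `COc1ncnc2c1c(-c1ccco1)cn2[C@@H]1O[C@H](CO)[C@@H](O)[C@H]1O` is the next to be measured. It differs from compound 3 in one place: furan-2-yl in place of 1-benzofuran-2-yl on an aromatic carbon. Among the measured compounds shown here, no measured step removes the six-membered aromatic ring of carbon only from the group at this position, so the expectation rests on analogy. Compound 1 carries a small five-membered aromatic ring at the same place, and its step to compound 3 is a 1.4-fold higher number from compound 1 to compound 3 (0.15 log units; within the scatter), within the scatter; compound 2, with ethynyl there, sits lower, and its step is a 3.1-fold higher number from compound 2 to compound 3 (0.49 log units; beyond the scatter), modest. Compound 4 is therefore expected to land near compound 1. The step expected here is a 1.4-fold lower number from compound 3 to compound 4 (0.16 log units; within the scatter), not clearly beyond the scatter. In this assay, compound 4 is expected to give 7500 nM, with a range from 3000 nM to 18000 nM.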

Compound 4, half-maximal inhibitory concentration: 160 nM
The estimate for compound 4 lay 47-fold (1.67 log units) above the measured number; the measured number lies below the stated range.
By their numbers in this assay, from the lowest: compound 4; then compound 2; then compounds 1 and 3 (each within the scatter of the next).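

In this assay, the three earlier compounds lay fairly close together, but compound 4 shows that a single change at this position can move the number a long way: replacing 1-benzofuran-2-yl with furan-2-yl, which takes away only the six-membered aromatic ring of carbon only, gives a 68-fold lower number from compound 3 to compound 4 (1.83 log units; beyond the scatter) on its own. A five-membered aromatic ring at this place is not enough for a low number, and compound 1 goes against that idea: furan-2-yl in place of thiophen-3-yl gives a 48-fold lower number from compound 1 to compound 4 (1.68 log units; beyond the scatter) and furan-2-yl in place of ethynyl gives a 22-fold lower number from compound 2 to compound 4 (1.34 log units; beyond the scatter) so the particular group matters here, not just the ring size. No measurement available here explains why furan-2-yl stands apart from the other three groups.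

The compounds shown leave open whether the low number depends on the ring oxygen or on how the ring is attached, a question that a thiophen-2-yl group at this place could help to separate. They also leave open how a non-aromatic group, such as an amine or a longer carbon chain, would behave at this position.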